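Removing one methyl: what compound 4 should show

This account rests on a few compounds, and the source may have more. Where it says the series, first, only, none or still open, it means among the compounds named here.

The measured compounds and their numbers in a functional assay on T47D cells (Homo sapiens) for inhibition, read by sulforhodamine B assay, with a stated time of 48 h (on this read-out lower numbers stand for stronger inhibition of growth and higher numbers for weaker inhibition of growth), are:
compound 1, `O=C(Nc1cccc(-n2cc(-c3ccncc3)c(-c3ccc(Cl)c(O)c3)n2)c1)Nc1cccc(C(F)(F)F)c1`, gives 2470 nM;
compound 2, `O=C(Nc1cccc(-n2cc(-c3ccncc3)c(-c3ccc(Cl)c(O)c3)n2)c1)Nc1ccc(Cl)c(Cl)c1`, gives 1550 nM;
compound 3, `COc1cc(-c2nn(-c3cccc(NC(=O)Nc4ccc(Cl)c(C(F)(F)F)c4)c3)cc2-c2ccncc2)ccc1Cl`, gives 1230 nM.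

Compound 3 holds the lowest of the three numbers, yet its gap to compound 2 and its gap to compound 1 both fall within the usual scatter, so the three cannot be ranked. Among the measured compounds shown here, the only step measured between single-change neighbours, a 1.6-fold lower number from compound 1 to compound 2 (0.20 log units; within the scatter), concerns the group on an amide-type nitrogen and likewise stays within the scatter.

Compound 4, `O=C(Nc1cccc(-n2cc(-c3ccncc3)c(-c3ccc(Cl)c(O)c3)n2)c1)Nc1ccc(Cl)c(C(F)(F)F)c1`, differs from compound 3 by hydrogen in place of methyl on an oxygen on an aromatic ring. For the measured compounds named here, no measured pair tests this hydrogen-for-methyl exchange on the aromatic oxygen, so the step from compound 1 to compound 2 bears on it only indirectly, as a sign that changes at the far end of this core have so far moved little. Compounds 1 and 2 already carry the hydroxy and sit within the scatter of compound 3. The step from compound 3 to compound 4 is therefore expected to be small, a 1.2-fold higher number from compound 3 to compound 4 (0.09 log units; within the scatter), with no clear direction. For compound 4 in this assay the estimate is 1500 nM, within 600 nM to 4000 nM.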

Compound 4, concentration for 50% growth inhibition: 1120 nM
Compound 4: the middle estimate sits 1.3-fold (0.13 log units) above what was measured; measured number inside the range.
By their numbers in this assay, from the lowest: compounds 4, 3, 2 and 1 (each within the scatter of the next, the first and the last beyond it).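

In this assay, among the compounds shown here, the step from methoxy to hydroxy on the 4-chloro-3-methoxyphenyl group, a 1.1-fold lower number from compound 3 to compound 4 (0.04 log units; within the scatter), gives the first direct reading at this position, and the two groups cannot be told apart there. For the compounds shown here, at the far end of the molecule, trifluoromethyl in place of chloro on an aromatic carbon gives a 1.4-fold lower number from compound 2 to compound 4 (0.14 log units; within the scatter), which also leaves the two compounds unranked, whereas chloro in place of hydrogen on an aromatic carbon gives a 2.2-fold lower number from compound 1 to compound 4 (0.34 log units; beyond the scatter), the only modest step among the single-change pairs and the only one that can be read as a real difference. Nothing available speaks to what lies behind these results.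

Going by these compounds, what an amine or an ethoxy group would do on this aromatic ring in place of the hydroxy remains open. On these data alone, it also remains open whether methoxy and hydroxy would again match when paired with the 3,4-dichlorophenyl or 3-(trifluoromethyl)phenyl group on the amide-type nitrogen, as the methoxy form appears here only in compound 3.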